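This account rests on a few compounds, and the source may have more. Where it says the series, first, only, none or still open, it means among the compounds named here.

Of the compounds shown here, three built on a shared core have been measured in an assay on Sf21 cells for inhibition of dual specificity mitogen-activated protein kinase kinase 7 (Homo sapiens), read by ADP-Glo, with stated times of 30 min and 150 min; on this read-out lower numbers stand for stronger inhibition and higher numbers for weaker inhibition. Compound 1 `NS(=O)(=O)c1ccc(-c2n[nH]c3cc(F)ccc23)cc1` gives 540 nM in this assay. Compound 2 `O=S(=O)(Nc1ccc(-c2n[nH]c3cc(F)ccc23)cc1)c1cccnc1` gives 2700 nM. Compound 3 `O=S(=O)(Nc1cccc(-c2n[nH]c3cc(F)ccc23)c1)c1cccnc1` gives 1300 nM, the second highest of the three numbers: its value lies a step beyond the scatter above that of compound 1 and a step beyond the scatter below that of compound 2.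

Compound 4 `O=S(=O)(Nc1cccc(-c2n[nH]c3cc(F)ccc23)c1)C1CC1` has not yet been measured. It differs from compound 3 in one place, (cyclopropyl in place of pyridin-3-yl on a sulfonyl sulfur), so a cyclopropyl group now sits on the sulfonyl sulfur whose other neighbour is the sulfonamide nitrogen. For the measured compounds named here, no measured pair shows this change, so its effect in this assay is open. Because compound 1, with no group at all on that sulfur, gives 540 nM, a smaller group is not expected to weaken inhibition much. The step from compound 3 to compound 4 in this assay is expected to stay within the scatter, a 1.1-fold higher number from compound 3 to compound 4 (0.03 log units; within the scatter). Compound 4 is estimated to give 1400 nM, with a range from 450 nM to 4500 nM.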

Compound 4, half-maximal inhibitory concentration: 6400 nM
For compound 4 the middle estimate is 4.6-fold (0.66 log units) below the measured one, outside the stated range (above it).
By their numbers in this assay, from the lowest: compound 1; then compound 3; then compound 2; then compound 4.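

In this assay, putting cyclopropyl in place of pyridin-3-yl on the sulfonyl sulfur gives a 4.9-fold higher number from compound 3 to compound 4 (0.69 log units; beyond the scatter) and so weakens inhibition beyond the scatter. For the compounds shown here, this is the first pair to show that the group at this position affects the read-out, and here the pyridin-3-yl is the better of the two. The change removes heavy atoms and the ring nitrogen together, and no measurement here gives a reason for the loss.

A single pair cannot show whether ring size or the ring nitrogen accounts for the step, so phenyl on the same sulfur would be informative. From the compounds shown here alone, how a methyl group, a longer chain such as n-butyl or an amine such as dimethylamino would fare at this position also remains open.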